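D4 agonist series: amide aryl variations, compound 4 outlook

The compounds below may be only part of what the source reports. "The series", "measured", "known", "first", "only" and "open" are said of these compounds alone.

Measured so far in a functional assay on HEK293 cells for agonist activity at D(4) dopamine receptor (Homo sapiens), read by FLIPR; on this read-out lower numbers stand for an effect already at smaller amounts and higher numbers for an effect only at larger amounts of compound:
- compound 1, `CSc1cccc(NC(=O)CN2CCC(c3cccc[n+]3[O-])CC2)c1`, gives 100 nM
- compound 2, `O=C(CN1CCC(c2cccc[n+]2[O-])CC1)Nc1ccc(F)cc1F`, gives 103 nM
- compound 3, `CC(C)Oc1cccc(NC(=O)CN2CCC(c3cccc[n+]3[O-])CC2)c1`, gives 555 nM

Compound 3 gives the highest number of the three; its gap to compound 2 and to compound 1 is beyond the scatter in both cases, so it sits clearly apart from the other two. Compound 1 and compound 2 lie within the scatter of each other and are not ordered.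

Compound 4, `O=C(CN1CCC(c2cccc[n+]2[O-])CC1)Nc1cccc(F)c1`, is not yet measured. It differs from compound 3 at one place: fluoro in place of isopropoxy on an aromatic carbon.

Going by the values given here, two measured steps bear on this. The step of a 5.6-fold higher number from compound 1 to compound 3 (0.74 log units; beyond the scatter) shows that isopropoxy on the aromatic carbon carries the higher number of compound 3, so removing isopropoxy should undo that move. The step of a 1.0-fold higher number from compound 1 to compound 2 (0.01 log units; within the scatter) shows that fluoro substitution on the amide aryl ring, as in compound 2, gives a number close to compound 1. Compound 4 is therefore expected to return toward the values of compound 1 and compound 2, a step estimated as a 4.6-fold lower number from compound 3 to compound 4 (0.67 log units; beyond the scatter). For compound 4 the expected value in this assay is 120 nM, with a range from 50 nM to 350 nM. Among the compounds with values here, no direct fluoro-for-isopropoxy step exists here, so the range is kept wide.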

Compound 4, half-maximal effective concentration: 160 nM
For compound 4 the middle estimate is 1.3-fold (0.12 log units) below the measured one, and the stated range covers the measured number.
By their numbers in this assay, from the lowest: compounds 1, 2 and 4 (each within the scatter of the next); then compound 3.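

In this assay, fluoro in place of isopropoxy on this aromatic carbon, meta to a large group, gives a 3.5-fold lower number from compound 3 to compound 4 (0.54 log units; beyond the scatter), so the high number of compound 3 is tied to isopropoxy and not to the shared core. Methylsulfanyl and fluoro at this carbon are not told apart, with a 1.6-fold higher number from compound 1 to compound 4 (0.20 log units; within the scatter), and the 3-fluorophenyl and 2,4-difluorophenyl amides are not told apart either, with a 1.6-fold higher number from compound 2 to compound 4 (0.19 log units; within the scatter), which leaves isopropoxy as the only group among the compounds shown that stands apart from the rest. Nothing at hand gives a reason for the isopropoxy step.

Going by these compounds, it remains open whether methoxy, ethoxy or a longer alkoxy chain on this carbon would read like compound 3 or like compound 4, which would show whether the step belongs to isopropoxy alone or to alkoxy groups more widely. On these data alone, it is equally open whether an amine or a carboxylic acid at this carbon would stay with compound 1, compound 2 and compound 4 or move away from them.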